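Cytotoxicity of Aryl Hydrazone Oxadiazole Thioethers in Liver Cells

The source may hold more compounds than are shown below. What is called first, only, known or untested is meant among the compounds shown, and "the series" means these compounds.

Compound 1 `COc1ccc(/C=N/NC(=O)CSc2nnc(-c3ccncc3)o2)cc1`: 15800 nM
Compound 2 `O=C(CSc1nnc(-c2ccncc2)o1)N/N=C/c1ccccc1[N+](=O)[O-]`: 24700 nM

In a functional assay on HepG2 cells (Homo sapiens) for cytotoxicity, read by MTT assay, with a stated time of 48 h (a higher number here means a weaker inhibitor, a lower number a stronger inhibitor), compound 1 gives 15800 nM, and compound 2 gives 24700 nM. Compound 2 stands highest of the two, yet the step of a 1.6-fold higher number from compound 1 to compound 2 (0.19 log units; within the scatter) is within the scatter. Compound 3 `O=C(CSc1nnc(-c2ccncc2)o1)N/N=C/c1cc(Br)cc(Br)c1O` differs from compound 2 by 3,5-dibromo-2-hydroxyphenyl in place of 2-nitrophenyl on a carbon with a double bond to nitrogen. Among the measured compounds shown here, the single measured step bears on it only loosely, as it swapped one aryl group for another at the same place and moved little. The number for compound 3 is therefore expected to shift by a 2.1-fold lower number from compound 2 to compound 3 (0.31 log units; beyond the scatter), towards a lower value but not far. Compound 3 is estimated at 12000 nM, within 3000 nM to 45000 nM.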

Compound 3, half-maximal inhibitory concentration: 6540 nM
Beside the measured number, compound 3's estimate is 1.8-fold (0.26 log units) above it; the range from low to high includes it.
By their numbers in this assay, from the lowest: compound 3; then compounds 1 and 2 (each within the scatter of the next).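

At the carbon with a double bond to nitrogen, the choice of aryl group now registers in this assay as more than scatter: 3,5-dibromo-2-hydroxyphenyl gives a 3.8-fold lower number from compound 2 to compound 3 (0.58 log units; beyond the scatter) and a 2.4-fold lower number from compound 1 to compound 3 (0.38 log units; beyond the scatter) as modest steps in the same direction. The earlier swap between the other two aryl groups showed no such separation. Nothing available accounts for this shift.

The dibromo and hydroxy parts enter together, and the compounds shown do not separate their contributions. On these data alone, how an amine or a carboxylic acid on this aryl ring would read also remains open.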